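The source may report more compounds than this note shows. Statements on the series, on what has been measured and on what is new or still open speak of the compounds shown alone.

Measured compounds:
- compound 1, `Nc1scc(CN2CCN(c3ccccc3C(F)(F)F)CC2)c1C(=O)c1ccc(Cl)cc1`, in a functional assay on CHO cells with adenosine receptor A1 (Homo sapiens) as the target, read by cAMP accumulation and immunoassay, with a stated time of 6 min, tested at 10 uM (on this read-out higher numbers stand for a weaker effect at the one concentration tested and lower numbers for a stronger effect), gives -60%
- compound 2, `Nc1scc(CN2CCN(c3ccc(C(F)(F)F)cc3)CC2)c1C(=O)c1cccc(C(F)(F)F)c1`, in this assay gives -47%

Of the two numbers, compound 1 holds the lowest, and the gap to compound 2 lies beyond the usual scatter of repeated measurements, so compound 1 shows the stronger effect of the two at the one concentration tested. Compound 2 differs from compound 1 in more than one place, so its number shows only where it stands, not what any single change does.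

The unmeasured compound 3, `Nc1scc(CN2CCN(c3cc(F)cc(F)c3)CC2)c1C(=O)c1ccc(Cl)cc1`, differs from compound 1 in one place: 3,5-difluorophenyl in place of 2-(trifluoromethyl)phenyl on an amine nitrogen in a ring. For the measured compounds named here, no measured pair with exactly this change exists, so the size of its step is not known from the data. The group that leaves and the group that enters are both single six-membered aromatic rings of carbon only, each without donors or acceptors, so a step of moderate size is expected, most likely towards a weaker effect, though a step within the scatter is also possible. For compound 3 the expected step is a number 15 percentage points higher from compound 1 to compound 3 (beyond the scatter). Compound 3 is estimated at -45%, in a range from -75% to -15%.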

Compound 3, a percentage reported as activity, at one concentration (the size of the read-out at that concentration, not a potency): -79%
For compound 3 the middle estimate is 34 percentage points above the measured one; measured number below the stated range.
By their numbers in this assay, from the lowest: compound 3; then compound 1; then compound 2.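

Swapping 2-(trifluoromethyl)phenyl for 3,5-difluorophenyl on the amine nitrogen of the six-membered non-aromatic ring with 2 nitrogen gives, in this assay, a number 19 percentage points lower from compound 1 to compound 3 (beyond the scatter) and so a stronger effect at the one concentration tested. For the compounds shown here, this is the first comparison here in which the rest of the molecule stays the same, so it shows that the group at this place can change the read-out by more than the usual scatter, and that a trifluoromethyl group on this ring is not needed for a strong effect. Nothing available explains why the read-out moves in this direction.

This single step cannot separate the loss of the trifluoromethyl group from the gain of the two fluorines, nor show how much the places of those fluorines matter. It also leaves open what an unsubstituted phenyl ring, or a phenyl ring carrying a methoxy group or a nitrile, would do at this place on the core of compound 1.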